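This account rests on a few compounds, and the source may have more. Where it says the series, first, only, none or still open, it means among the compounds named here.

Measured so far:
- compound 1, `NS(=O)(=O)c1ccccc1-c1cnc(C(=O)CCCCCCc2ccccc2)o1`: 1500 nM
- compound 2, `O=C(CCCCCCc1ccccc1)c1ncc(-c2ccccc2C(=O)C(F)(F)F)o1`: 5000 nM
- compound 3, `Nc1cccc(-c2cnc(C(=O)CCCCCCc3ccccc3)o2)c1`: 19 nM

These three compounds share a core and were tested in an assay (Rattus norvegicus) for inhibition of Fatty-acid amide hydrolase 1 (Homo sapiens); a lower number here means a stronger inhibitor, a higher number a weaker inhibitor. Compound 3 stands at the low end of the three numbers: its gap to compound 1 and its gap to compound 2 are both far beyond the scatter, so compound 3 is the strongest inhibitor here.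

Compound 4, `O=C(CCCCCCc1ccccc1)c1ncc(-c2ccc(O)cc2)o1`, is not yet measured. It differs from compound 3 in one place: 4-hydroxyphenyl in place of 3-aminophenyl on an aromatic carbon. Within the data shown here, the only measured step, a 3.3-fold higher number from compound 1 to compound 2 (0.52 log units; beyond the scatter), swaps two other groups on a different part of the aromatic ring and does not bear directly on this change. Compounds 1 and 2 show that other aryl substituents give much higher numbers than compound 3, but neither carries a hydroxyl. Among the measured compounds shown here, with no direct precedent, the expectation for compound 4 is a small move, possibly within the scatter, estimated as a 2.1-fold higher number from compound 3 to compound 4 (0.32 log units; beyond the scatter). Compound 4 is therefore expected to give about 40 nM, in the range 10 nM to 200 nM.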

Compound 4, inhibition constant: 140 nM
The estimate for compound 4 lay 3.5-fold (0.54 log units) below the measured number; the range from low to high includes it.
By their numbers in this assay, from the lowest: compound 3; then compound 4; then compound 1; then compound 2.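

In this assay, this position on the shared core responds strongly to a change that leaves the simple counts untouched: a 7.4-fold higher number from compound 3 to compound 4 (0.87 log units; beyond the scatter), yet 3-aminophenyl and 4-hydroxyphenyl have the same number of heavy atoms, hydrogen-bond donors and hydrogen-bond acceptors, and neither carries a net charge. Those counts alone therefore do not set the number at this position. No measurement shown here gives a reason for the step.

This single change swaps nitrogen for oxygen and also shifts the group's place on the phenyl ring, so the compounds shown cannot say how much of the step belongs to each. Matched compounds with 4-aminophenyl or 3-hydroxyphenyl at this position would separate the two contributions.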